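A few compounds are considered here, and "the series" means these few. Any claim that something is new, unique, unknown or untested is made for them only; others in the source may bear on it.

Measured so far in an assay on isolated protein for inhibition of Retinaldehyde dehydrogenase 3 (Homo sapiens); on this read-out lower numbers stand for stronger inhibition and higher numbers for weaker inhibition:
compound 1, `Cn1ncc2c(=O)n(-c3ccccc3)c(SC(C)(C)c3ccccc3)nc21`: 1390 nM
compound 2, `COc1cccc(C(C)Sc2nc3c(cnn3C)c(=O)n2-c2ccccc2)c1`: 174 nM

In this assay compound 2 gives the lowest of the two numbers; compound 1 gives a higher number, and that gap lies beyond the usual scatter. Among the measured compounds shown here, no pair of measured compounds differs in only one place, so no single step is known from measurement.

Compound 3, `CC(Sc1nc2c(cnn2C)c(=O)n1-c1ccccc1)c1cccc(F)c1`, differs from compound 2 by fluoro in place of methoxy on an aromatic carbon. For the measured compounds named here, nothing measured speaks directly to this exchange; the two numbers show only that the group present in compound 2 goes with the lower value. The step in this assay is expected to be modest, toward a somewhat higher number, and is estimated at a 1.5-fold higher number from compound 2 to compound 3 (0.17 log units; within the scatter), which would not exceed the scatter. For compound 3 the estimate is 260 nM, with a range of 100 nM to 700 nM.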

Compound 3, half-maximal inhibitory concentration: 128 nM
The estimate for compound 3 lay 2.0-fold (0.31 log units) above the measured number, and the stated range covers the measured number.
By their numbers in this assay, from the lowest: compounds 3 and 2 (each within the scatter of the next); then compound 1.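

In this assay, fluoro in place of methoxy on an aromatic carbon gives a 1.4-fold lower number from compound 2 to compound 3 (0.13 log units; within the scatter) so the two groups are not told apart at this position, and the methoxy oxygen is not needed to hold a value of this level. Among the compounds shown here, the change on the sulfur, 1-(3-fluorophenyl)ethyl in place of 1-methyl-1-phenylethyl, gives an 11-fold lower number from compound 1 to compound 3 (1.04 log units; beyond the scatter) and is the first step that can be read as lying beyond the scatter. No measurement at hand accounts for either step.

The large step joins two changes, the ring fluoro and the loss of a methyl from the 1-methyl-1-phenylethyl group, and the compounds shown do not separate them. On these data alone, how this ring position responds to an amine, a carboxylic acid or a nitrile remains open.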